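Sulfonyl substituent variation on a shared core

The compounds below may be only part of what the source reports. "The series", "measured", "known", "first", "only" and "open" are said of these compounds alone.

Measured compounds:
compound 1 `COC(=O)CC(=O)N1N=C(c2ccc(N3CCN(C)CC3)cc2)CC1c1ccc(N(C)C)cc1` with -0.4%
compound 2 `CN1CCN(c2ccc(C3=NN(S(C)(=O)=O)C(c4ccc(N(C)C)cc4)C3)cc2)CC1` with 0.6%

In a functional assay on MDA-MB-231 cells (Homo sapiens) for inhibition, read by sulforhodamine B assay, tested at 10 uM (a higher number here means more inhibition at the concentration tested (going by the name of the read-out), a lower number less inhibition), compound 2 gives 0.6%, the higher of the two numbers, with compound 1 as its nearest neighbour at -0.4%; the two values sit within the scatter of each other, so no order between them is claimed. Within the data shown here, the one measured step, a number 1 percentage points higher from compound 1 to compound 2 (within the scatter), exchanges the group on the ring amine nitrogen and moves nothing beyond the scatter.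

Compound 3 `Cc1ccc(S(=O)(=O)N2N=C(c3ccc(N4CCN(C)CC4)cc3)CC2c2ccc(N(C)C)cc2)cc1` is not yet measured. It differs from compound 2 by 4-methylphenyl in place of methyl on a sulfonyl sulfur. Among the measured compounds shown here, no measured step touches the substituent on the sulfonyl sulfur, so the only guidance is that the one change made so far at this nitrogen, from compound 1 to compound 2, left the read-out flat. On that basis the step of a number 2.4 percentage points higher from compound 2 to compound 3 (within the scatter) is expected to stay within the scatter. Compound 3 is therefore estimated at 3%, with a range from -10% to 20%.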

Compound 3, a percentage reported as inhibition, at one concentration (the size of the read-out at that concentration, not a potency): 10.7%
For compound 3 the middle estimate is 7.7 percentage points below the measured one, within the range that was stated.
By their numbers in this assay, from the lowest: compounds 1 and 2 (each within the scatter of the next); then compound 3.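

Changing the substituent on the sulfonyl sulfur moves the read-out in this assay, where the earlier change at this nitrogen did not: 4-methylphenyl in place of methyl gives a number 10.1 percentage points higher from compound 2 to compound 3 (beyond the scatter) in this pair. The (4-methylphenyl)sulfonyl group also separates from the ((methoxycarbonyl)methyl)carbonyl group, with a number 11.1 percentage points higher from compound 1 to compound 3 (beyond the scatter) on the same ring nitrogen, whereas compound 2 also carries a sulfonyl group and stays within the scatter of compound 1, so a sulfonyl group alone is not sufficient. Nothing available explains the step.

On these data alone, whether the step belongs to the aromatic ring or to its methyl group remains open, and a plain phenyl, 4-chlorophenyl or a butyl chain on the sulfur would bear on that. With compound 3 at 10.7% at one concentration, the compounds shown also give no potency for any member of the series.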